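Dropping the fluorine from compound 2

The source may hold more compounds than are shown below. What is called first, only, known or untested is meant among the compounds shown, and "the series" means these compounds.

Compound 1 `CCOc1ccc(NC2=CC(=O)c3ncncc3C2=O)cc1` and compound 2 `O=C1C(Nc2ccc(F)cc2)=CC(=O)c2ncncc21` share one core and differ in a single substituent. In a functional assay on A549 cells (Homo sapiens) for cytotoxicity, read by MTT assay, with a stated time of 72 h (on this read-out lower numbers stand for stronger inhibition and higher numbers for weaker inhibition), compound 1 gives 0.16 ug/mL, while compound 2 gives 1.08 ug/mL; the move is a 6.8-fold higher number from compound 1 to compound 2 (0.83 log units; beyond the scatter). Within the data shown here, compound 2 thus holds the higher of the two numbers so far, with compound 1 its only point of comparison at a lower value. Compound 3 `O=C1C(Nc2ccccc2)=CC(=O)c2ncncc21` is the unmeasured analogue in which (hydrogen in place of fluoro on an aromatic carbon), the site lying on an aromatic carbon of a six-membered aromatic ring of carbon only, para to a large group. Among the measured compounds shown here, no measured step covers this exact change; the one step available, from compound 1 to compound 2, exchanged ethoxy for fluoro and says nothing about fluoro against hydrogen. For compound 3 in this assay the expected step is therefore a 1.1-fold higher number from compound 2 to compound 3 (0.05 log units; within the scatter), most likely within the scatter and of uncertain direction. Compound 3 is estimated at 1.2 ug/mL, within a range from 0.4 ug/mL to 3.6 ug/mL.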

Compound 3, half-maximal inhibitory concentration: 0.02 ug/mL
Estimate against measurement, compound 3: 60-fold (1.78 log units) above; the whole stated range lies above it.
By their numbers in this assay, from the lowest: compound 3; then compound 1; then compound 2.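

At this site on the aromatic carbon, para to a large group, the earlier pair gave no sign of how far the number could fall: in this assay the hydrogen of compound 3 gives the lowest number of the three, with a 54-fold lower number from compound 2 to compound 3 (1.73 log units; beyond the scatter) and an 8.0-fold lower number from compound 1 to compound 3 (0.90 log units; beyond the scatter) as its steps. Both substituted compounds therefore stand on the weaker side of the unsubstituted one, and ethoxy, which had looked favourable against fluoro, no longer does so against hydrogen. Among these compounds, nothing available explains why the loss of a single fluorine moves the number so far.

From the compounds shown here alone, whether a chloro group, a methoxy group or an amine at this site would fall near compound 3 or near compound 2 remains open. So does whether this order would hold on any other cell line.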